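The compounds below may be only part of what the source reports. "The series", "measured", "known", "first", "only" and "open" are said of these compounds alone.

Measured so far in a physicochemical assay for lipophilicity, read by HPLC, at pH 2; on this read-out lower numbers stand for lower lipophilicity and higher numbers for higher lipophilicity:

compound 1 `O=C(O)c1cnn(-c2cccc(-c3cccc(C(=O)N(CC4CC4)CC4CC4)c3F)c2)c1C1CC1` — 3.5
compound 2 `CCCC1CCCCN1C(=O)C1CCCC(c2cccc(-n3ncc(C(=O)O)c3C3CC3)c2)C1` — 4.1

Among the measured compounds shown here, of the two numbers known in this assay, compound 1 stands lowest. Compound 2 sits higher, and the gap between the two values is beyond the usual scatter; the two structures differ in more than one place, so the gap says nothing about any single change.

Compound 3 `CN(C)C(=O)c1cccc(-c2cccc(-n3ncc(C(=O)O)c3C3CC3)c2)c1F` is not yet measured. It is obtained from compound 1 by one change: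

dimethylamino in place of bis(cyclopropylmethyl)amino on a carbonyl carbon

The group that leaves is much larger than the one that enters, and both are uncharged amide substituents without donors or acceptors. A step of this kind is expected to lower the read-out in this assay by a clear margin, well beyond the scatter, rather than leave it unchanged.

Compound 3 is therefore estimated at 2, with a range of 1.5 to 2.5 in this assay. The step that this estimate means, a number 1.50 log units lower from compound 1 to compound 3 (beyond the scatter), is expected to be a fall beyond the scatter, measured from the value of compound 1 at 3.5.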

Compound 3, distribution coefficient: 1.3
The estimate for compound 3 lay 0.70 log units above the measured number; measured number below the stated range.
By their numbers in this assay, from the lowest: compound 3; then compound 1; then compound 2.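

In this assay, the group on the carbonyl carbon is now shown to have a large influence on the read-out: replacing bis(cyclopropylmethyl)amino with dimethylamino gives a single-change step (a number 2.20 log units lower from compound 1 to compound 3 (beyond the scatter)). The earlier pair, compound 1 and compound 2, differ in more than one place and could not isolate any one change, whereas this step is tied to one place, and both the leaving and entering groups have no hydrogen-bond donors or acceptors and no net charge. No measurement shown here bears on why the step is this large.

The compounds shown give only the two end points of this change, so it remains open whether diethylamino or a single cyclopropylmethyl paired with methyl on the same carbonyl carbon would give a value between those of compound 3 and compound 1. On these data alone, it also remains open how the read-out would respond to a morpholine amide or a hydroxyethyl chain, since neither of the two groups compared here carries a hydrogen-bond donor or acceptor.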